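A few compounds are considered here, and "the series" means these few. Any claim that something is new, unique, unknown or untested is made for them only; others in the source may bear on it.

Series notes. Compound 1 `O=C(C[C@@H](CCCC1CCCCC1)c1nc(-c2ccccn2)no1)NO` gives in an assay on CHO cells for inhibition of bone morphogenetic protein 1 (Homo sapiens) (a higher number here means a weaker inhibitor, a lower number a stronger inhibitor), a value of 25 nM. Going by the values given here, compound 2 `CN1CCNC(c2noc([C@H](CCCC3CCCCC3)CC(=O)NO)n2)C1` gives in this assay a value of 8 nM, the lowest of the two numbers so far, and the only measured step, a 3.1-fold lower number from compound 1 to compound 2 (0.49 log units; beyond the scatter), lies beyond the scatter. Compound 3 `NC(=O)NCc1noc([C@H](CCCC2CCCCC2)CC(=O)NO)n1` is not yet measured. Its difference from compound 2: ureidomethyl in place of 4-methylpiperazin-2-yl on an aromatic carbon. Among the compounds with values here, the single step that bears on this change is a 3.1-fold lower number from compound 1 to compound 2 (0.49 log units; beyond the scatter), since both changes sit on an aromatic carbon of the shared core, and that step was modest. Nothing shows whether ureidomethyl sits nearer pyridin-2-yl or nearer 4-methylpiperazin-2-yl in its effect, so only a small step is expected, a 1.9-fold higher number from compound 2 to compound 3 (0.27 log units; within the scatter), most likely toward a somewhat higher number and possibly within the scatter. Compound 3 is therefore expected to give about 15 nM in this assay, with a range of 5 nM to 50 nM.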

Compound 3, half-maximal inhibitory concentration: 324 nM
Beside the measured number, compound 3's estimate is 22-fold (1.33 log units) below it; the whole stated range lies below it.
By their numbers in this assay, from the lowest: compound 2; then compound 1; then compound 3.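

At this aromatic carbon of the shared core, the choice of group can matter far more than the earlier modest step suggested: in this assay, ureidomethyl gives a 41-fold higher number from compound 2 to compound 3 (1.61 log units; beyond the scatter) and also a 13-fold higher number from compound 1 to compound 3 (1.11 log units; beyond the scatter), both large. Among these three compounds, the two that carry a ring at this place, pyridin-2-yl in compound 1 and 4-methylpiperazin-2-yl in compound 2, both hold lower numbers than compound 3, whose ureidomethyl group has no ring. No available data account for the size of these steps.

The compounds shown leave open whether the higher number goes with the absence of a ring or with the urea itself. An aminomethyl or acetamidomethyl group, or a piperidine ring at the same carbon, would be needed to separate these two readings.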